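The source may hold more compounds than are shown below. What is called first, only, known or untested is meant among the compounds shown, and "the series" means these compounds.

Compounds measured so far:
compound 1, `c1ccc(CNc2[nH]ccc3ncnc2-3)cc1`, 75%
compound 2, `CN(C)c1[nH]ccc2ncnc1-2`, 8%
compound 3, `[N-]=[N+]=Nc1[nH]ccc2ncnc1-2`, 20%

In a functional assay (Homo sapiens) for inhibition of Nucleic Acid, tested at 100 uM (on this read-out higher numbers stand for more inhibition at the one concentration tested (going by the name of the read-out) and lower numbers for less inhibition), compound 3 stands second highest of the three numbers. Its nearest neighbour is compound 2, whose value of 8% lies a step below; the furthest is compound 1 at 75%, well above. Going by the values given here, the one measured step that leads to compound 3, a number 12 percentage points higher from compound 2 to compound 3 (beyond the scatter), exchanges dimethylamino for azido and is modest.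

Compound 4, `Nc1[nH]ccc2ncnc1-2`, is the next compound. amino in place of azido on an aromatic carbon This change leaves the azido behind and puts a small amino group in its place, on the same aromatic carbon of the shared core. No measured step replaces azido by amino, so nothing shown bears on it directly; the only related step, from a substituted amine to azido, was modest, and a return to a smaller amine gives no clear direction. A change no larger than the scatter is therefore expected, in either direction, that is a number 5 percentage points higher from compound 3 to compound 4 (within the scatter). Compound 4 is estimated at 25%, within a range from 5% to 55%.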

Compound 4, a percentage reported as inhibition, at one concentration (the size of the read-out at that concentration, not a potency): 60%
The estimate for compound 4 lay 35 percentage points below the measured number, and the stated range ends below it.
By their numbers in this assay, from the lowest: compound 2; then compound 3; then compound 4; then compound 1.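

Going by these compounds alone, the group on this aromatic carbon matters far more than the earlier compounds could show: a number 40 percentage points higher from compound 3 to compound 4 (beyond the scatter) is a large step, and so is a number 52 percentage points higher from compound 2 to compound 4 (beyond the scatter). The smallest group here, amino, therefore does not sit near the low end with azido and dimethylamino, but in the upper part of the series, so a small group on this carbon is compatible with strong inhibition. Amino also brings a hydrogen-bond donor where azido has none, but that is only a count, and nothing measured here explains the jump.

Going by these compounds, it remains open whether a single short chain on the nitrogen, as in methylamino or ethylamino, would keep the number seen for compound 4. Also open, on these data alone, is whether a hydroxyl or a methoxy group on the same carbon could take the place of amino.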